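The source may report more compounds than this note shows. Statements on the series, on what has been measured and on what is new or still open speak of the compounds shown alone.

Measured compounds:
Compound 1, `CC1CCCc2c1[nH]c(=O)c(C#N)c2-c1cccn1C`: in a functional assay on NCI-H522 cells (Homo sapiens) for inhibition, read by sulforhodamine B assay, with a stated time of 48 h (on this read-out lower numbers stand for stronger inhibition of growth and higher numbers for weaker inhibition of growth), compound 1 gives only a limit, > 100000 nM.
Compound 2, `CC1CCCc2c1nc(N)c(C#N)c2-c1cccn1C`: in this assay compound 2 gives 66100 nM.
Compound 3, `Cn1cccc1-c1cc(-c2cccs2)nc(N)c1C#N`: in this assay compound 3 gives only a limit, > 100000 nM.

Compound 3 thus sits at the edge of what this assay can report, and it shares this with compound 1, since (the limit of > 100000 nM in this assay, at which 2 of the 3 values shown sit). Only compound 2 gives a number, and that number speaks of weak growth inhibition. Compound 4, `Cn1cccc1-c1cc(-c2ccccc2)nc(N)c1C#N`, is not yet measured. It differs from compound 3 in one place: phenyl in place of thiophen-2-yl on an aromatic carbon. Among the compounds with values here, no step between measured compounds is known here, so the size of the change can only be guessed. Compound 4 is expected to remain a weak inhibitor, with the step from compound 3 estimated as a number no higher from compound 3 to compound 4 (the limit leaves the size open). The expected value for compound 4 is 100000 nM, within a range of 30000 nM to 300000 nM.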

Compound 4, concentration for 50% growth inhibition: 61600 nM
The estimate for compound 4 lay 1.6-fold (0.21 log units) above the measured number; the range from low to high includes it.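

In this assay, phenyl in place of thiophen-2-yl gives an at least 1.6-fold lower number from compound 3 to compound 4 (0.21 log units; that floor lies within the scatter) at this position next to the ring nitrogen. This is the only one-place comparison shown, and it shows that a phenyl here can give a measurable number, although the growth inhibition remains weak. On these data alone, compound 3 gives only a limit, so the true size of the step stays unknown: the limit of > 100000 nM in this assay, at which 2 of the 4 values shown sit.

Still open, as far as these compounds go, is whether an amine or a carboxylic acid on the phenyl, or a longer chain at this position, would give stronger growth inhibition.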